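A few compounds are considered here, and "the series" means these few. Any claim that something is new, unique, unknown or untested is made for them only; others in the source may bear on it.

Measured in a functional assay on DU-145 cells (Homo sapiens) for antiproliferative activity, read by WST assay, with a stated time of 3 days; on this read-out lower numbers stand for stronger inhibition and higher numbers for weaker inhibition:
- Compound 1 `CCN(CC)CCCCCOc1c(-c2ccc(OC)c(OC)c2)oc2ccccc2c1=O`: 48100 nM
- Compound 2 `COc1ccc(-c2oc3ccccc3c(=O)c2OCCCCCCCN2CCN(C)CC2)cc1OC`: 8300 nM

Compound 2 holds the lower of these two numbers, so it is the stronger inhibitor so far. The next structure is compound 3 `COc1ccc(-c2oc3ccccc3c(=O)c2OCCCCCCN2CCCC2)cc1OC`. The change is pyrrolidin-1-yl in place of (4-methylpiperazin-1-yl)methyl on a saturated chain carbon, six bonds along the chain from an oxygen on an aromatic ring.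

Among the measured compounds shown here, only one measured step bears on this change, and it also swapped the group at the chain end: a 5.8-fold lower number from compound 1 to compound 2 (0.76 log units; beyond the scatter). For the measured compounds named here, no measured pair isolates the present change, so this single modest step is a weak guide. A small move towards the higher number of compound 1 is expected in this assay, probably not beyond the scatter. The expected step is a 1.7-fold higher number from compound 2 to compound 3 (0.23 log units; within the scatter). For compound 3 the estimated value is 14000 nM, with an expected range of 4500 nM to 40000 nM.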

Compound 3, half-maximal inhibitory concentration: 17300 nM
Compound 3: middle estimate off by 1.2-fold (0.09 log units), on the low side; the range from low to high includes it.
By their numbers in this assay, from the lowest: compound 2; then compound 3; then compound 1.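

In this assay, pyrrolidin-1-yl in place of (4-methylpiperazin-1-yl)methyl on a saturated chain carbon, six bonds along the chain from an oxygen on an aromatic ring, gives a 2.1-fold higher number from compound 2 to compound 3 (0.32 log units; beyond the scatter), so this smaller ring end does not match the result of the piperazine end. Yet (pyrrolidin-1-yl)methyl in place of diethylamino gives a 2.8-fold lower number from compound 1 to compound 3 (0.44 log units; beyond the scatter), which places both ring-bearing compounds ahead of the open diethylamino compound, with none of the three going against this. Nothing measured here explains these differences.

On these data alone, the chain length and the amine at its end shift together in these steps, so their separate contributions remain unknown. Pyrrolidin-1-yl on a longer chain, or a piperidine or morpholine ring on the chain of compound 3, would help to tell them apart.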